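A few compounds are considered here, and "the series" means these few. Any claim that something is new, unique, unknown or untested is made for them only; others in the source may bear on it.

Measured so far in a functional assay on the whole organism for inhibition, with Rattus norvegicus as the target; a higher number here means a weaker inhibitor, a lower number a stronger inhibitor

- compound 1 `O=C1ON=C(c2cccs2)/C1=C/c1ccc(O)cc1` gives 4200 nM
- compound 2 `COc1ccc(C2=NOC(=O)/C2=C\c2cccs2)cc1` gives 11000 nM

Compound 1 has the lower of these two numbers, and the gap to compound 2 lies beyond the scatter. Compound 3 `O=C1ON=C(c2cccs2)/C1=C/c1ccc(O)c(O)c1` differs from compound 1 by one change, hydroxy in place of hydrogen on an aromatic carbon, ortho to a hydroxy group (hydroxy in place of hydrogen on an aromatic carbon). For the measured compounds named here, no measured pair shows this change, so the expectation is a judgement. A modest step toward a lower number in this assay is expected, estimated as a 2.1-fold lower number from compound 1 to compound 3 (0.32 log units; beyond the scatter) in size. For compound 3 the estimated value is 2000 nM, with 600 nM to 6000 nM as the expected range.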

Compound 3, half-maximal inhibitory concentration: 3400 nM
The estimate for compound 3 lay 1.7-fold (0.23 log units) below the measured number; low and high end bracket the measured number.
By their numbers in this assay, from the lowest: compounds 3 and 1 (each within the scatter of the next); then compound 2.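

Replacing hydrogen with hydroxy on the aromatic carbon ortho to a hydroxy group gives a 1.2-fold lower number from compound 1 to compound 3 (0.09 log units; within the scatter) in this assay and so does not separate compound 3 from compound 1. This position therefore accepts a hydroxy group without a change that can be read in this assay. No measurement on hand offers an explanation for this result.

On these data alone, whether an amine or a carboxylic acid at this position would give a number beyond the scatter of compound 1 remains open. So does the effect of a fluorine atom there.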